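The source may report more compounds than this note shows. Statements on the series, on what has been measured and on what is new or still open speak of the compounds shown alone.

Measured so far:
compound 1 `CCCNC(=O)c1cccc2nc(OCC)n(Cc3ccc(-c4ccccc4-c4nnn[nH]4)cc3)c12`, giving 32.6%
compound 2 `CCOc1nc2cccc(C(=O)Nc3ccc(OC)cc3)c2n1Cc1ccc(-c2ccccc2-c2nnn[nH]2)cc1`, giving 25.8%

Both numbers come from an assay on isolated protein for inhibition of NEDD8-activating enzyme E1 regulatory subunit (Homo sapiens), read by Western blot, with stated times of 10 min and 30 min, tested at 25 uM; on this read-out higher numbers stand for more inhibition at the one concentration tested (going by the name of the read-out) and lower numbers for less inhibition. Compound 2 stands within the usual scatter of compound 1: a number 6.8 percentage points lower from compound 1 to compound 2 (within the scatter). Compound 3 `CCOc1nc2cccc(C(=O)NOCc3ccccc3)c2n1Cc1ccc(-c2ccccc2-c2nnn[nH]2)cc1` differs from compound 2 in one place: benzyloxy in place of 4-methoxyphenyl on an amide-type nitrogen. For the measured compounds named here, the one measured step also swaps the group on this amide-type nitrogen and stayed within the scatter, so for compound 3 no step beyond the scatter is expected in this assay; the expected step is a number 2.2 percentage points higher from compound 2 to compound 3 (within the scatter). Compound 3 is therefore estimated at 28%, with a range from 10% to 48%.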

Compound 3, a percentage reported as inhibition, at one concentration (the size of the read-out at that concentration, not a potency): 39.8%
Estimate against measurement, compound 3: 11.8 percentage points below; the range from low to high includes it.
By their numbers in this assay, from the lowest: compounds 2, 1 and 3 (each within the scatter of the next, the first and the last beyond it).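

The group on this amide-type nitrogen can move the number after all: benzyloxy and 4-methoxyphenyl have the same heavy-atom count and the same ring, joined differently, yet the swap gives a step beyond the scatter (a number 14 percentage points higher from compound 2 to compound 3 (beyond the scatter)). Propyl, by contrast, stays within the scatter of benzyloxy (a number 7.2 percentage points higher from compound 1 to compound 3 (within the scatter)). No measured evidence here explains the difference.

Which part of benzyloxy goes with the higher number stays open. A plain benzyl or methoxy group on this nitrogen would help to separate the two parts.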